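Ether arm replaces a methyl on the chain

The compounds below may be only part of what the source reports. "The series", "measured", "known", "first", "only" and "open" are said of these compounds alone.

Compound 2 `CCC(Nc1nnc(-c2ccc(OC)cc2)o1)[C@H]1CC[C@@H](c2ccnc3ccc(C(F)(F)F)cc32)CC1` is the weaker of the two compounds measured in an assay on blood for inhibition of Indoleamine 2,3-dioxygenase 1 (Homo sapiens), read by mass spectrometry, with a stated time of 18 h (a lower number here means a stronger inhibitor, a higher number a weaker inhibitor), where compound 2 gives 50 nM. Compound 1 `CCC(c1nc2ncc(Cl)cc2[nH]1)[C@H]1CC[C@@H](c2ccnc3ccc(C(F)(F)F)cc32)CC1` differs from it at more than one place, and in this assay compound 1 gives 21 nM, a gap beyond the usual scatter. Compound 3 `CCOCC(Nc1nnc(-c2ccc(OC)cc2)o1)[C@H]1CC[C@@H](c2ccnc3ccc(C(F)(F)F)cc32)CC1` has not yet been measured; it carries ethoxy in place of methyl on a saturated chain carbon, two bonds along the chain from a nitrogen on an aromatic ring and a saturated ring carbon. No single-change comparison of this kind is at hand, so the change is expected to shift the number only modestly, if at all, and more likely upward than downward. Compound 3 is therefore estimated at 70 nM, within a range from 25 nM to 200 nM, a step of a 1.4-fold higher number from compound 2 to compound 3 (0.15 log units; within the scatter) expected to sit near the edge of the scatter.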

Compound 3, half-maximal inhibitory concentration: 96 nM
Compound 3: the middle estimate sits 1.4-fold (0.14 log units) below what was measured; the measured number falls inside the stated range.
By their numbers in this assay, from the lowest: compound 1; then compounds 2 and 3 (each within the scatter of the next).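

The single-change comparison at this position, ethoxy in place of methyl on a saturated chain carbon, gives a 1.9-fold higher number from compound 2 to compound 3 (0.28 log units; within the scatter) in this assay. So on this chain, a group of 3 heavy atoms carrying 1 hydrogen-bond acceptor can stand where methyl stood without a step beyond the scatter. Nothing measured here accounts for this result. On these data alone, whether a hydroxyl, an amine or a longer propoxy chain at this place would behave the same remains open, as does whether ethoxy would give a similar step on the core of compound 1.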